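Hydrazone aryl swaps on a shared oxadiazole-thioether scaffold

The source may report more compounds than this note shows. Statements on the series, on what has been measured and on what is new or still open speak of the compounds shown alone.

Measured compounds:
compound 1 `Cc1ccc(/C=N/NC(=O)CSc2nnc(-c3ccncc3)o2)cc1` — 10000 nM
compound 2 `O=C(CSc1nnc(-c2ccncc2)o1)N/N=C/c1cccc(F)c1` — 19500 nM

In a functional assay on HepG2 cells (Homo sapiens) for cytotoxicity, read by MTT assay, with a stated time of 48 h (a higher number here means a weaker inhibitor, a lower number a stronger inhibitor), compound 1 gives 10000 nM and compound 2 gives 19500 nM. For the measured compounds named here, the only step seen so far, a 2.0-fold higher number from compound 1 to compound 2 (0.29 log units; within the scatter), lies within the scatter, so compound 2 and compound 1 cannot be told apart. Compound 3 `O=C(CSc1nnc(-c2ccncc2)o1)N/N=C/c1ccccc1O` is the next analogue. It differs from compound 2 in one place: 2-hydroxyphenyl in place of 3-fluorophenyl on a carbon with a double bond to nitrogen. Going by the values given here, no measured step involves a 2-hydroxyphenyl group, and the one aryl swap seen moved nothing beyond the scatter. Compound 3 is therefore expected to sit close to compound 2, with an estimated step of a 1.3-fold lower number from compound 2 to compound 3 (0.11 log units; within the scatter) and a value of 15000 nM (range 5000 nM to 45000 nM).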

Compound 3, half-maximal inhibitory concentration: 3510 nM
The estimate for compound 3 lay 4.3-fold (0.63 log units) above the measured number, and the stated range ends above it.
By their numbers in this assay, from the lowest: compound 3; then compounds 1 and 2 (each within the scatter of the next).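

In this assay, the group on a carbon with a double bond to nitrogen can shift the number beyond the scatter: the change shows a 5.6-fold lower number from compound 2 to compound 3 (0.74 log units; beyond the scatter), and the comparison with the other earlier compound shows a 2.8-fold lower number from compound 1 to compound 3 (0.45 log units; beyond the scatter). The entering 2-hydroxyphenyl carries a hydrogen-bond donor and acceptor that the leaving 3-fluorophenyl lacks, though this count alone does not establish what drives the step. No evidence at hand accounts for the difference. Still open, going by these compounds, is whether the hydroxyl group itself or its place on the ring matters; a 2-methoxyphenyl or a 4-hydroxyphenyl group on this carbon would bear on that question.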